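Same Methyl Removal, Repeated on a Second Core

The source may hold more compounds than are shown below. What is called first, only, known or untested is meant among the compounds shown, and "the series" means these compounds.

Three compounds have been examined in a functional assay on the whole organism (strain Swiss) with Mus musculus as the target, in the maximal electroshock model, with a stated time of 2 h, at a dose of 300 mg/kg by the intraperitoneal route; a higher number here means a stronger effect of the compound at the dose given, a lower number a weaker effect. Compound 1 `CC(C(=O)N1CCN(c2ccc(C(F)(F)F)cc2)CC1)N1C(=O)CCC1=O` gives 0% in this assay. Compound 2 `CCC(C(=O)N1CCN(c2ccc(C(F)(F)F)cc2)CC1)N1C(=O)CCC1=O` gives 0%, and compound 3 `CCC(C(=O)N1CCN(c2ccc(F)cc2)CC1)N1C(=O)CCC1=O` gives 0%. The step of no change at the digits printed from compound 2 to compound 1 (within the scatter) carries the change (hydrogen in place of methyl on a saturated chain carbon, two bonds along the chain from an amide-type nitrogen in a ring and a carbonyl carbon). The step of no change at the digits printed from compound 2 to compound 3 (within the scatter) carries the change (fluoro in place of trifluoromethyl on an aromatic carbon), and this is also how the core of compound 2 differs from the core of compound 3. Compound 3 stands level with compounds 1 and 2 at the digits reported, within the scatter of both.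

Compound 4 `CC(C(=O)N1CCN(c2ccc(F)cc2)CC1)N1C(=O)CCC1=O` has not yet been measured in this assay. It differs from compound 3 by hydrogen in place of methyl on a saturated chain carbon, two bonds along the chain from an amide-type nitrogen in a ring and a carbonyl carbon, the same change that leads from compound 2 to compound 1, at a place described in the same words. Among the four compounds this change occurs twice, and where it has been measured it made no change at the digits printed from compound 2 to compound 1 (within the scatter).

From compound 3 to compound 4 a step of no change at the digits printed from compound 3 to compound 4 (within the scatter) is expected, because the step of no change at the digits printed from compound 2 to compound 1 (within the scatter) showed the same change leaving the read-out unaltered on the core of compound 2, and because compound 3 gives 0% as its starting point. Compound 4 is therefore estimated to give 0% in this assay. The expected range for compound 4 runs from 0% to 10%.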

Compound 4, a percentage reported as activity, at one dose (the size of the read-out at that dose, not a potency): 50%
For compound 4 the middle estimate is 50 percentage points below the measured one, outside the stated range (above it).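

In this assay, for the compounds shown here, the change from ethyl to methyl did not carry from one core to the other, giving no change at the digits printed from compound 2 to compound 1 (within the scatter) on the trifluoromethyl core but a number 50 percentage points higher from compound 3 to compound 4 (beyond the scatter) on the fluoro core: the same change on two cores in this assay, no change at the digits printed (within the scatter) from compound 2 to compound 1 and a number 50 percentage points higher (beyond the scatter) from compound 3 to compound 4, 50 percentage points apart, beyond the scatter of two such steps Read the other way, fluoro in place of trifluoromethyl depends in the same way on the chain it is paired with, giving no change at the digits printed from compound 2 to compound 3 (within the scatter) with ethyl on the chain but a number 50 percentage points higher from compound 1 to compound 4 (beyond the scatter) with methyl: the same change on two cores in this assay, no change at the digits printed (within the scatter) from compound 2 to compound 3 and a number 50 percentage points higher (beyond the scatter) from compound 1 to compound 4, 50 percentage points apart, beyond the scatter of two such steps Both contrasts rest on compound 4 alone, the only compound of the four that combines the methyl chain with the fluoro group, so they show that the two changes do not act independently here, but they do not show why, give no rule for any further core, and say nothing of potency, as the read-out comes from a single dose.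

The compounds shown leave open whether the effect in compound 4 is tied to fluoro itself or would also appear with chloro, methoxy or nitrile on that aromatic carbon. They also leave open how a longer chain such as propyl, or a chain carbon carrying no alkyl group at all, would behave alongside fluoro.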